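Trifluoromethyl for methyl on the aromatic ring of compound 2

This account rests on a few compounds, and the source may have more. Where it says the series, first, only, none or still open, it means among the compounds named here.

Compound 2 `Cc1ccc(-c2cn(CCCO)nn2)cc1` reaches only a limit in a functional assay on B16 cells (Mus musculus) for cytotoxicity, read by MTT assay, with a stated time of 48 h (a lower number here means a stronger inhibitor, a higher number a weaker inhibitor), where compound 2 gives > 100000 nM. Compound 3 `Cc1ccc(-c2cn(Cc3ccccc3)nn2)cc1` likewise sits at a limit; in this assay compound 3 gives > 100000 nM. The step that the two limits leave unreadable from compound 2 to compound 3 therefore cannot be read, because both values sit at the limit of > 100000 nM in this assay, at which 2 of the 3 values shown sit. Compound 1 `CC1(C)OCC(Cn2cc(-c3ccc(C(F)(F)F)cc3)nn2)O1`, which carries a trifluoromethyl on its six-membered aromatic ring and a different group on the chain bound to the aromatic nitrogen, gives 13500 nM in this assay. Compound 4 `OCCCn1cc(-c2ccc(C(F)(F)F)cc2)nn1` differs from compound 2 by trifluoromethyl in place of methyl on an aromatic carbon. Within the data shown here, no measured step covers this exchange directly, so the expectation rests on compound 1 with 13500 nM. For compound 4 a step of an at least 2.0-fold lower number from compound 2 to compound 4 (0.30 log units; that floor lies within the scatter) towards a stronger value is expected, with little confidence. Compound 4 is estimated at 50000 nM, within 12000 nM to 100000 nM, and may again be reported only as a limit.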

Compound 4, half-maximal inhibitory concentration: > 100000 nM
Compound 4: only a limit was reported (the forecaster's own chance of this, stated with the estimate: 40%); at least 2.0-fold (0.30 log units) between middle value and limit.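

In this assay compound 4 gives > 100000 nM, which is a limit. With trifluoromethyl on the aromatic ring of both compounds, 2-hydroxyethyl in place of 2,2-dimethyl-1,3-dioxolan-4-yl gives a step of an at least 7.4-fold higher number from compound 1 to compound 4 (0.86 log units; beyond the scatter), so trifluoromethyl alone does not bring a readable value. The step for trifluoromethyl in place of methyl cannot be read because both compounds sit at the limit: the limit of > 100000 nM in this assay, at which 3 of the 4 values shown sit.

Going by these compounds, whether an amine, a carboxylic acid or a longer chain in place of 2-hydroxyethyl would give a readable value stays open. Also open, on these data alone, is what methyl on the aromatic ring would do alongside 2,2-dimethyl-1,3-dioxolan-4-yl.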